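Replacing the Terminal Sulfone with a Carboxylic Acid

The source may hold more compounds than are shown below. What is called first, only, known or untested is meant among the compounds shown, and "the series" means these compounds.

The series shares one core and varies only the group at the end of the chain. Compound 1 `CCc1cc(C(C)=O)c(O)cc1OCCCCCCSC` gives 14% in an assay on isolated protein for binding affinity to leukotriene B4 receptor 1 (Homo sapiens), tested at 1 uM; a higher number here means more inhibition at the concentration tested (going by the name of the read-out), a lower number less inhibition. Compound 2 `CCc1cc(C(C)=O)c(O)cc1OCCCCCC[S+](C)[O-]` gives 50%, and compound 3 `CCc1cc(C(C)=O)c(O)cc1OCCCCCCS(C)(=O)=O` gives 62%. Compound 3 stands highest of the three: the step of a number 48 percentage points higher from compound 1 to compound 3 (beyond the scatter) and the step of a number 12 percentage points higher from compound 2 to compound 3 (beyond the scatter) are both beyond the scatter, as is a number 36 percentage points higher from compound 1 to compound 2 (beyond the scatter).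

Compound 4 `CCc1cc(C(C)=O)c(O)cc1OCCCCCCC(=O)O` differs from compound 3 at the same chain position: carboxy in place of methylsulfonyl on a saturated chain carbon, six bonds along the chain from an oxygen on an aromatic ring. Going by the values given here, no measured step contains a carboxy group, so the three steps bear on this change only indirectly, all sitting at the same place on the chain. Among the compounds with values here, they show that each exchange at this position so far moved the read-out upward, in large or modest amounts, and that the terminal group governs the inhibition strongly.

Because compound 3 already gives 62%, the room above it is limited. Compound 4 is expected to give 78%, with a range from 55% to 98%. The step of a number 16 percentage points higher from compound 3 to compound 4 (beyond the scatter) is thus expected to be a modest rise, though a value within the scatter of compound 3 would not be surprising.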

Compound 4, a percentage reported as inhibition, at one concentration (the size of the read-out at that concentration, not a potency): 38%
Beside the measured number, compound 4's estimate is 40 percentage points above it, and the stated range ends above it.
By their numbers in this assay, from the lowest: compound 1; then compound 4; then compound 2; then compound 3.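

In this assay the exchange of methylsulfonyl for carboxy gave a number 24 percentage points lower from compound 3 to compound 4 (beyond the scatter) and so brought a downward move at this chain position, which none of the earlier steps had shown. The carboxy group also gave a number 12 percentage points lower from compound 2 to compound 4 (beyond the scatter) against the sulfur group of compound 2, yet it gave a number 24 percentage points higher from compound 1 to compound 4 (beyond the scatter) against methylsulfanyl, so the carboxy compound falls inside the spread of the three sulfur-bearing end groups, not above them, and a change at this place can lower the read-out as well as raise it. Nothing measured on these compounds accounts for this order of the end groups.

The compounds shown leave open whether a methyl ester or a primary amide of the carboxy group, or a sulfonamide or a tetrazole in its place, would stay near compound 4 or come closer to compound 3. They also leave open how a shorter or a longer chain would alter the read-out for the carboxy group and for methylsulfonyl, as all four compounds carry the end group at the same distance from the oxygen on the aromatic ring.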